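A Second Isopropyl on an Inactive Thio Core

The source may report more compounds than this note shows. Statements on the series, on what has been measured and on what is new or still open speak of the compounds shown alone.

- compound 1 `CC1CCSC1=O`: 91 mg/kg
- compound 2 `CC(C)C1CCSC1=O`: > 500 mg/kg
- compound 3 `CC(C)C1(C)CCSC1=O`: > 500 mg/kg
- compound 4 `CC(C)C1(C(C)C)CCSC1=O`: not yet measured

In a functional assay on the whole organism with Mus musculus as the target, in the maximal electroshock model (on this read-out higher numbers stand for an effect only at larger amounts of compound and lower numbers for an effect already at smaller amounts), compound 3 gives only a limit, > 500 mg/kg, and not a number. Compound 2 also gives only a limit, > 500 mg/kg. The data therefore end at a ceiling: the limit of > 500 mg/kg in this assay, at which 2 of the 3 values shown sit.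

Compound 4 differs from compound 3 in one place, isopropyl in place of methyl on a saturated ring carbon. The same exchange has been measured once, as an at least 5.4-fold higher number from compound 1 to compound 2 (0.73 log units; beyond the scatter). Adding isopropyl in place of hydrogen gave an at least 5.4-fold higher number from compound 1 to compound 3 (0.73 log units; beyond the scatter). Adding methyl gave a step that the two limits leave unreadable from compound 2 to compound 3, so that step offers no guidance.

Both readable steps point to larger doses in this assay, so a further move in that direction is expected, though its size is uncertain. The expected change is a step that the limit leaves unreadable from compound 3 to compound 4, and the assay will most likely report only a limit again. For compound 4 the estimated value is 700 mg/kg, with an expected range from 300 mg/kg to 2000 mg/kg.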

Compound 4, dose for half-maximal effect: > 500 mg/kg
Compound 4 ended at the assay's limit (the forecaster's own chance of this, stated with the estimate: 80%); the middle value lies beyond the limit too.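

In this assay compound 4 gives > 500 mg/kg, a limit and not a number. Its steps from compound 2 and from compound 3 therefore cannot be read. The compounds shown leave open whether compound 2, compound 3 and compound 4 truly differ from one another at all.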